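From 4-bromophenoxy to 4-fluorophenoxy: working notes

The compounds below may be only part of what the source reports. "The series", "measured", "known", "first", "only" and "open" are said of these compounds alone.

Three compounds have been taken into a functional assay on MGC-803 cells (Homo sapiens) for antiproliferative activity, read by CCK-8 assay, with a stated time of 72 h (a lower number here means a stronger inhibitor, a higher number a weaker inhibitor), and only one of them gives a number. In this assay compound 1 `C/C(=N\O)c1ccc(OCc2ccc(C(=O)NO)cc2)cc1` has the entry "not determined" (no result reported). Compound 3 `Nc1ccccc1NC(=O)c1ccc(CN2CCc3cc(Br)ccc32)cc1` gives 7390 nM in this assay.

Compound 2 `Nc1ccccc1NC(=O)c1ccc(COc2ccc(Br)cc2)cc1` gives > 32000 nM, which is a limit of the assay and not a number. Its place on the scale is therefore known only as a limit: the limit of > 32000 nM in this assay, at which 1 of the 3 values shown sits.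

Compound 4 `Nc1ccccc1NC(=O)c1ccc(COc2ccc(F)cc2)cc1` has not yet been measured. It keeps the structure of compound 2 except for fluoro in place of bromo on an aromatic carbon, para to a large group: fluoro in place of bromo on an aromatic carbon.

Within the data shown here, no measured step gives the size of this exchange. The expected change an at least 1.2-fold lower number from compound 2 to compound 4 (0.10 log units; that floor lies within the scatter) is therefore none beyond the scatter, with no direction assumed. This expectation rests on the limit of compound 2 at > 32000 nM. Another result reported only as a limit would fit that expectation.

For compound 4 the estimated value is 25000 nM, with an expected range from 8000 nM to 60000 nM.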

Compound 4, half-maximal inhibitory concentration: 4970 nM
Beside the measured number, compound 4's estimate is 5.0-fold (0.70 log units) above it, outside the stated range (below it).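

Fluoro in place of bromo on an aromatic carbon, para to a large group, brings compound 4 to 4970 nM in this assay and gives the first readable step in the series: an at least 6.4-fold lower number from compound 2 to compound 4 (0.80 log units; beyond the scatter), so the group at this position does bear on the antiproliferative read-out. Compound 2 gives > 32000 nM as a limit of the assay and not a number. The step is therefore a floor, and its full size remains unread, although its direction is fixed: the limit of > 32000 nM in this assay, at which 1 of the 4 values shown sits.

With bromo and fluoro the only groups shown at this position, the compounds do not say whether a chloro group, a methoxy group, an amine or a plain hydrogen there would fall nearer compound 2 or nearer compound 4. Going by these compounds, it also remains open whether the same exchange of bromo for fluoro would carry the same weight on the core of compound 3, which has a different link to the halogen-bearing ring.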